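This account rests on a few compounds, and the source may have more. Where it says the series, first, only, none or still open, it means among the compounds named here.

Measured so far in an assay on isolated protein for inhibition of 2-Hydroxyacid oxidase 2 (Rattus norvegicus); a higher number here means a weaker inhibitor, a lower number a stronger inhibitor:
Compound 1, `Cc1n[nH]c(C(=O)O)c1Cc1ccc(Oc2ccccc2)cc1`: 500 nM
Compound 2, `Cc1n[nH]c(C(=O)O)c1Cc1cccc(-c2ccc(C(N)=O)cc2)c1`: 200 nM

Two compounds built on a shared core have numbers in this assay. Compound 1 gives 500 nM, the higher of the two. Compound 2 gives 200 nM, a lower number, and the gap between the two lies beyond the scatter, so of this pair compound 2 is the stronger inhibitor. Going by the values given here, the two differ in more than one place, so no single step between them can be read.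

Compound 3, `Cc1n[nH]c(C(=O)O)c1Cc1ccc(-c2ccc(F)cc2)cc1`, has not yet been measured. It differs from compound 1 in one place: 4-fluorophenyl in place of phenoxy on an aromatic carbon. Among the compounds with values here, no measured pair shows this change on its own, and compound 2, which also carries a directly linked aryl ring, differs from compound 1 in other places as well, so it is only a loose pointer. The expected step is a 1.7-fold lower number from compound 1 to compound 3 (0.22 log units; within the scatter), a modest move toward a lower number, of a size near the scatter. Compound 3 is therefore estimated at 300 nM, with a range from 80 nM to 1200 nM.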

Compound 3, half-maximal inhibitory concentration: 400 nM
Compound 3: the middle estimate sits 1.3-fold (0.12 log units) below what was measured; the measured number falls inside the stated range.
By their numbers in this assay, from the lowest: compounds 2, 3 and 1 (each within the scatter of the next, the first and the last beyond it).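

In this assay, going by these compounds alone, the first change that can be read on its own gives a 1.3-fold lower number from compound 1 to compound 3 (0.10 log units; within the scatter), so replacing phenoxy with 4-fluorophenyl on this aromatic carbon, para to a large group, leaves the number within the scatter. The exchange removes the oxygen of phenoxy and its hydrogen-bond acceptor and brings in a fluorine, while the number of heavy atoms and the six-membered aromatic ring of carbon stay the same, so at this position neither that oxygen nor that acceptor is shown to matter for the reading in this assay. Nothing in the available data explains why the two groups read alike.

Compound 2 differs from both other compounds in more than one place, so its steps to them cannot be read, and the origin of its number remains unassigned. Because oxygen and fluorine changed together, their separate contributions stay unresolved, and a plain phenyl, a 4-chlorophenyl or a phenyl ring carrying an amine or a carboxylic acid at this position would be needed to show whether the substituent on the outer ring can move the number beyond the scatter.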